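This account rests on a few compounds, and the source may have more. Where it says the series, first, only, none or still open, it means among the compounds named here.

For the measured compounds named here, in a functional assay on MC-38 cells (Mus musculus) for antiproliferative activity, read by colorimetric assay and MTT assay (a higher number here means a weaker inhibitor, a lower number a stronger inhibitor), compound 1 (`COc1ccc(S(=O)(=O)Nc2cccc3cc[nH]c23)cc1`) gives 1.5 ug/mL, the higher of the two numbers so far, and compound 2 (`COc1ccc(S(=O)(=O)Nc2ccc(Cl)c3cc[nH]c23)cc1`) gives 0.65 ug/mL. Compound 3 (`COc1ccc(S(=O)(=O)Nc2cccc3cc(O)[nH]c23)cc1`) differs from compound 1 by hydroxy in place of hydrogen on an aromatic carbon, with the hydroxy next to the ring nitrogen. Going by the values given here, the only measured step, a 2.3-fold lower number from compound 1 to compound 2 (0.36 log units; beyond the scatter), is modest and brings chloro rather than hydroxy, at another carbon, so it bears only loosely on this change. No step beyond the scatter is therefore expected in this assay. The expected step is a 1.3-fold higher number from compound 1 to compound 3 (0.12 log units; within the scatter). The estimate for compound 3 is 2 ug/mL, with an expected range of 0.6 ug/mL to 7 ug/mL.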

Compound 3, half-maximal inhibitory concentration: 0.22 ug/mL
Compound 3: middle estimate off by 9.1-fold (0.96 log units), on the high side; measured number outside the range, below it.
By their numbers in this assay, from the lowest: compound 3; then compound 2; then compound 1.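

In this assay, hydroxy next to the ring nitrogen gives a 6.8-fold lower number from compound 1 to compound 3 (0.83 log units; beyond the scatter), so a change on the five-membered aromatic ring alone moves the number beyond the scatter. The earlier step, with chloro, lay at another carbon and said nothing about this one. Nothing at hand accounts for the step.

As far as these compounds go, it remains open whether the hydroxy itself matters or whether a methoxy or an amine at this carbon would give a similar number. Also open, from the compounds shown here alone, is how hydroxy at this carbon behaves together with the chloro of compound 2.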